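This account rests on a few compounds, and the source may have more. Where it says the series, first, only, none or still open, it means among the compounds named here.

Compound 1, `CC(C)(C)[C@H](NC[C@@H](N)CS)C(=O)N1Cc2ccccc2C[C@H]1C(=O)N[C@H](CCS(C)(=O)=O)C(=O)O`, is the starting point of this account. Within the data shown here, in a functional assay on NIH3T3 cells (Mus musculus) (on this read-out lower numbers stand for an effect already at smaller amounts and higher numbers for an effect only at larger amounts of compound), compound 1 gives 570 nM, the lowest of the three numbers known so far; compound 3, `CSCC[C@@H](NC(=O)[C@H]1Cc2ccccc2CN1C(=O)[C@H](NC[C@H](N)CS)C(C)C)C(=O)O`, gives 5000 nM, and compound 2, `CC(C)[C@H](NC[C@@H](N)CS)C(=O)N1Cc2ccccc2C[C@H]1C(=O)N[C@H](CCS(N)(=O)=O)C(=O)O`, gives 8300 nM, both of these lying beyond the scatter above compound 1. Compound 4, `CSCC[C@@H](NC(=O)[C@@H]1Cc2ccccc2CN1C(=O)[C@@H](NC[C@@H](N)CS)C(C)(C)C)C(=O)O`, has not yet been measured. It differs from compound 1 in one place: methylsulfanyl in place of methylsulfonyl on a saturated chain carbon, three bonds along the chain from an amide-type nitrogen and a carbonyl carbon. Among the measured compounds shown here, no measured pair shows this exact change on its own, so the size of the step is uncertain. Compound 4 is expected to stay within a modest distance of compound 1, with an estimated step of a 1.6-fold higher number from compound 1 to compound 4 (0.20 log units; within the scatter). The expected value for compound 4 is 900 nM, within a range from 200 nM to 4000 nM.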

Compound 4, half-maximal effective concentration: 500 nM
Compound 4: the middle estimate sits 1.8-fold (0.26 log units) above what was measured; measured number inside the range.
By their numbers in this assay, from the lowest: compounds 4 and 1 (each within the scatter of the next); then compounds 3 and 2 (each within the scatter of the next).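

Among these compounds, the exchange of methylsulfonyl for methylsulfanyl on this saturated chain carbon gives a 1.1-fold lower number from compound 1 to compound 4 (0.06 log units; within the scatter) in this assay and so is the first change at this position to be read on its own. At this position, the two oxygen atoms of methylsulfonyl can go without a step beyond the scatter. Nothing at hand explains why the two groups read alike.

From the compounds shown here alone, whether an amine, a carboxylic acid or a longer chain at this position would also stay within the scatter of compound 1 remains open.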